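Swapping a benzoyl for a phenylsulfonyl on an indole acrylonitrile

A few compounds are considered here, and "the series" means these few. Any claim that something is new, unique, unknown or untested is made for them only; others in the source may bear on it.

Measured compounds:
- compound 1 `N#C/C(=C\c1c(-c2ccccc2)[nH]c2ccccc12)C(=O)c1ccccc1`: "not determined" (no result reported)
- compound 2 `CCOC(=O)C(=Cc1c(-c2ccccc2)[nH]c2ccccc12)C(=O)OCC`: 3800 nM
- compound 3 `COc1ccc(-c2[nH]c3ccc(OC)cc3c2C=C(C#N)C#N)cc1`: 324 nM

In a functional assay on SK-MEL-5 cells (Homo sapiens) for inhibition, read by sulforhodamine B assay, with a stated time of 48 h (a higher number here means a weaker inhibitor of growth, a lower number a stronger inhibitor of growth), compound 2 gives 3800 nM and compound 3 gives 324 nM, a gap between them that is beyond the usual scatter. In this assay compound 1 gives "not determined" (no result reported), so it cannot be placed against either of them. Compound 4 `N#C/C(=C\c1c(-c2ccccc2)[nH]c2ccccc12)S(=O)(=O)c1ccccc1` differs from compound 1 by a single change: phenylsulfonyl in place of benzoyl on a double-bonded chain carbon bound to a double-bonded chain carbon and a triple-bonded carbon. Within the data shown here, with no value for compound 1, no step in this assay can be given a size or a direction from compound 1 to compound 4. Resting only on compound 2 and compound 3, compound 4 is expected to land near 1200 nM in this assay, within a range of 250 nM to 6000 nM.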

Compound 4, concentration for 50% growth inhibition: 1820 nM
The estimate for compound 4 lay 1.5-fold (0.18 log units) below the measured number, within the range that was stated.
By their numbers in this assay, from the lowest: compound 3; then compound 4; then compound 2.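

Among these compounds, with compound 1 giving "not determined" (no result reported) in this assay, no step from compound 1 to compound 4 can be read. From the compounds shown here alone, what swapping benzoyl for phenylsulfonyl does to growth inhibition stays open. Nothing shown here accounts for the value of compound 4.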